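From naphthalen-1-yl to 4-(tert-butyl)phenyl on a sulfonyl sulfur

The source may report more compounds than this note shows. Statements on the series, on what has been measured and on what is new or still open speak of the compounds shown alone.

Compound 1 `O=C(/C=C/c1c[nH]c2ccccc12)c1ccncc1` gives 49300 nM
Compound 2 `O=C(/C=C/c1cn(S(=O)(=O)c2cccc([N+](=O)[O-])c2)c2ccccc12)c1ccncc1` gives 42600 nM
Compound 3 `O=C(/C=C/c1cn(S(=O)(=O)c2cccc3ccccc23)c2ccccc12)c1ccncc1` gives 62900 nM

In a functional assay on HepG2 cells (Homo sapiens) for antiproliferative activity, read by MTT assay, with a stated time of 48 h (on this read-out higher numbers stand for weaker inhibition and lower numbers for stronger inhibition), compound 3 (62900 nM) stands within the scatter of both compound 1 and compound 2, so the three values cannot be ranked. Compound 4 `CC(C)(C)c1ccc(S(=O)(=O)n2cc(/C=C/C(=O)c3ccncc3)c3ccccc32)cc1` has not yet been measured. It differs from compound 3 by 4-(tert-butyl)phenyl in place of naphthalen-1-yl on a sulfonyl sulfur, and the count of that change reads 4-(tert-butyl)phenyl in place of naphthalen-1-yl on a sulfonyl sulfur in full.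

For the measured compounds named here, the one measured exchange on this sulfonyl sulfur is a 1.5-fold higher number from compound 2 to compound 3 (0.17 log units; within the scatter) and it offers no change to carry over. Compound 1, which has no sulfonyl group, gives 49300 nM and so also lies within the scatter of the two sulfonyl compounds. Going by the values given here, nothing measured so far shows a group on the sulfonyl sulfur moving the number, and no direction can be drawn from these data. A step beyond the scatter is therefore not expected in this assay for this exchange. The estimated step is a 1.3-fold lower number from compound 3 to compound 4 (0.10 log units; within the scatter) and it is expected to stay within the scatter. For compound 4 the expected value is 50000 nM with an estimated range of 25000 nM to 100000 nM around it.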

Compound 4, half-maximal inhibitory concentration: 27000 nM
Estimate against measurement, compound 4: 1.9-fold (0.27 log units) above; the measured number falls inside the stated range.
By their numbers in this assay, from the lowest: compounds 4, 2, 1 and 3 (each within the scatter of the next, the first and the last beyond it).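

In this assay, for the compounds shown here, 4-(tert-butyl)phenyl in place of naphthalen-1-yl on a sulfonyl sulfur gives a 2.3-fold lower number from compound 3 to compound 4 (0.37 log units; beyond the scatter), the first step at this position to pass beyond the scatter, so the group held there can move the number, if only modestly. The two groups both hold 10 heavy atoms, all carbon, and differ in that the entering group has one six-membered aromatic ring and the leaving group has two, yet the same entering group in place of 3-nitrophenyl gives a 1.6-fold lower number from compound 2 to compound 4 (0.20 log units; within the scatter), which stays within the scatter, so the change shows against only one of the two earlier sulfonyl groups. No measurement at hand accounts for the step seen with this exchange.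

The compounds shown leave open whether the step belongs to the tert-butyl group or to the loss of the second aromatic ring, a question that a plain phenyl on the sulfonyl sulfur would help to separate. They also leave open how a phenyl bearing an amine or a carboxylic acid would read in this assay.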